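Working notes: from compound 2 to compound 3

The compounds below may be only part of what the source reports. "The series", "measured", "known", "first", "only" and "open" are said of these compounds alone.

Compound 1 `COc1cccc(/C=C2\CCC/C(=C\c3ccccc3Br)C2=O)c1OC` gives 9700 nM in a functional assay on MCF7 cells (Homo sapiens) for cytotoxicity, read by MTT assay, with a stated time of 72 h; a higher number here means a weaker inhibitor, a lower number a stronger inhibitor
Compound 2 `COc1ccc(/C=C2\CCC/C(=C\c3ccccc3Br)C2=O)cc1OC` gives 9500 nM in this assay

Compound 2 stands within the scatter of compound 1, so these two numbers give no ranking and mark one shared level. The next compound to be read is compound 3 `COc1ccc(/C=C2\CCC/C(=C\c3ccc(OC)c(OC)c3)C2=O)cc1` with 4-methoxyphenyl in place of 2-bromophenyl on a double-bonded chain carbon bound to a double-bonded ring carbon as its difference from compound 2.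

Among the measured compounds shown here, no measured pair in this small set shows what such an exchange does. The expectation therefore starts from compound 2 at 9500 nM and has to stay wide. In this assay a small step toward a higher number is expected, possibly still inside the scatter and not far beyond it. The estimated move is a 1.3-fold higher number from compound 2 to compound 3 (0.10 log units; within the scatter) and no large change in either direction is expected. The expected value for compound 3 is 12000 nM with an estimated range from 4000 nM to 35000 nM in this measurement.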

Compound 3, half-maximal inhibitory concentration: 7800 nM
Compound 3: the middle estimate sits 1.5-fold (0.19 log units) above what was measured, and the stated range covers the measured number.
By their numbers in this assay, from the lowest: compounds 3, 2 and 1 (each within the scatter of the next).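

In this assay, 4-methoxyphenyl in place of 2-bromophenyl on a double-bonded chain carbon bound to a double-bonded ring carbon gives a 1.2-fold lower number from compound 2 to compound 3 (0.09 log units; within the scatter), the only single-place step shown so far. At this place, the read-out does not separate the two groups, even though 4-methoxyphenyl carries a hydrogen-bond acceptor and 2-bromophenyl carries none, so compound 3 stays on the level of compound 2 and this exchange gives no ranking. Nothing measured here offers an explanation for this result.

Among the compounds shown here, with only one exchange at this place, it remains open whether any group there can move the number in this assay beyond the scatter, for example an aminophenyl or carboxyphenyl group, or a longer chain in place of the aromatic ring. It is also open whether the same exchange would give a similar step on a core carrying a different methoxy arrangement on its other aromatic ring, since the single step shown has only one such partner.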